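Ester variation on a dihydropyrimidinone series at adenosine A2b

The source may hold more compounds than are shown below. What is called first, only, known or untested is meant among the compounds shown, and "the series" means these compounds.

Measured so far:
compound 1, `CC1=C(C(=O)OCc2ccccc2)C(c2ccsc2)NC(=O)N1`: 44%
compound 2, `CCCOC(=O)C1=C(C)N(C)C(=O)NC1c1cccs1`: 1%

In an assay on membranes from HEK293 cells for displacement of a labelled ligand from adenosine receptor A2b (Homo sapiens), read by scintillation counting, with a stated time of 30 min, tested at 1 uM (a lower number here means less inhibition, a higher number more inhibition at the concentration tested (going by the name of the read-out)), compound 1 gives 44%, the higher of the two numbers recorded. In this assay compound 2 gives 1%, a gap that lies beyond the scatter; compound 2 differs from compound 1 in more than one place, so no single step can be read from that pair.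

Compound 3, `CCC(C)OC(=O)C1=C(C)NC(=O)NC1c1ccsc1`, has not yet been measured. It differs from compound 1 as follows: sec-butyl in place of benzyl on an oxygen next to a carbonyl group. Nothing measured in this assay isolates the ester group on its own, so the direction of the step rests on the two numbers above alone. The expectation is a loss of inhibition from compound 1 to compound 3, estimated at a number 22 percentage points lower from compound 1 to compound 3 (beyond the scatter) in this assay, beyond the scatter but not to the floor. Compound 3 is expected to give about 22% in this assay, within 5% to 40%.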

Compound 3, a percentage reported as inhibition, at one concentration (the size of the read-out at that concentration, not a potency): 39%
Estimate against measurement, compound 3: 17 percentage points below; the range from low to high includes it.
By their numbers in this assay, from the lowest: compound 2; then compounds 3 and 1 (each within the scatter of the next).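

At the oxygen next to a carbonyl group, sec-butyl in place of benzyl gives a number 5 percentage points lower from compound 1 to compound 3 (within the scatter) in this assay. The six-membered aromatic ring of benzyl is therefore not needed on this oxygen for inhibition at this level, since sec-butyl, with no ring, reads the same within the scatter. No measurement on record bears on why these two esters read alike.

Still open, as far as these compounds go, is whether a longer chain on this oxygen, a carboxylic acid or an amide in place of the ester would hold inhibition at this level. Compound 2, at 1%, differs from compound 1 in more than one place, so the shared core's contribution to that low value cannot be separated from that of its ester.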